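This account rests on a few compounds, and the source may have more. Where it says the series, first, only, none or still open, it means among the compounds named here.

Measured compounds:
- Compound 1 `C[C@H](N)C(=O)Nc1cccc(-c2nn3c(=O)cc(N4CCNCC4)nc3s2)c1`: 5870 nM
- Compound 2 `O=C(O)c1cccc(-c2nn3c(=O)cc(N4CCNCC4)nc3s2)c1`: 80000 nM

In a functional assay on cells (Platelet) for inhibition (on this read-out lower numbers stand for stronger inhibition and higher numbers for weaker inhibition), compound 2 gives 80000 nM, the higher of the two numbers. Compound 3 `O=C(O)CNc1cccc(-c2nn3c(=O)cc(N4CCNCC4)nc3s2)c1` differs from it in one place: (carboxymethyl)amino in place of carboxy on an aromatic carbon. Among the measured compounds shown here, only one measured step bears on this change: a 14-fold higher number from compound 1 to compound 2 (1.13 log units; beyond the scatter), a large step at that same aromatic carbon. Compound 3 keeps a carboxy group but, like compound 1, has an amino nitrogen on that carbon, so a partial move back seems likely. The expected change is a 2.7-fold lower number from compound 2 to compound 3 (0.43 log units; beyond the scatter), toward a lower number. For compound 3 the estimated value is 30000 nM, with an expected range of 8000 nM to 100000 nM.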

Compound 3, half-maximal inhibitory concentration: 2000 nM
Estimate against measurement, compound 3: 15-fold (1.18 log units) above; measured number below the stated range.
By their numbers in this assay, from the lowest: compound 3; then compound 1; then compound 2.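

In this assay, (carboxymethyl)amino in place of carboxy on this aromatic carbon gives a 40-fold lower number from compound 2 to compound 3 (1.60 log units; beyond the scatter), so a carboxy group in the molecule does not by itself go with a high number. Carboxymethyl in place of (1-aminoethyl)carbonyl on the nitrogen gives a 2.9-fold lower number from compound 1 to compound 3 (0.47 log units; beyond the scatter), which shows that this nitrogen does not need the amine-bearing group to reach a low number. Nothing measured here explains these shifts. Still open, going by these compounds, is whether a plain amine on this carbon, or a longer chain on the nitrogen ending in a carboxylic acid, would lower the number further.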